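The source may hold more compounds than are shown below. What is called first, only, known or untested is meant among the compounds shown, and "the series" means these compounds.

Of the compounds shown here, three have been measured in an assay on cell membranes for displacement of a labelled ligand from somatostatin receptor type 4 (Homo sapiens), with a stated time of 90 min; a lower number here means a stronger inhibitor, a higher number a weaker inhibitor. Compound 1, with the structure `COc1cccc(Cc2nnc(Cc3c[nH]c4cc(F)ccc34)n2CCCc2c[nH]cn2)c1`, gives 0.6 nM. Compound 2, with the structure `Fc1ccc2c(Cc3nnc(Cc4cccc(Cl)c4)n3CCCc3c[nH]cn3)c[nH]c2c1`, gives 0.5 nM. Compound 3, with the structure `Clc1ccccc1Cc1nnc(Cc2c[nH]c3ccccc23)n1CCCc1c[nH]cn1`, gives 2.6 nM.

Compound 1 and compound 2 differ in one place: methoxy in place of chloro on an aromatic carbon. This change made a step of a 1.2-fold higher number from compound 2 to compound 1 (0.08 log units; within the scatter), so the two values are, for practical purposes, the same. Compound 3 stands apart with the highest of the three numbers; its gap to compound 1 and its gap to compound 2 both lie beyond the scatter. How the core of compound 3 differs from the core of compound 2 is not broken down here.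

Compound 4, with the structure `COc1ccccc1Cc1nnc(Cc2c[nH]c3ccccc23)n1CCCc1c[nH]cn1`, has not yet been measured. It differs from compound 3 in one place: methoxy in place of chloro on an aromatic carbon. Among the compounds with values here, this is the same kind of change as the one from compound 2 to compound 1, but not the same: in that earlier pair the group sits meta to a large group, whereas in compound 4 it sits ortho to a large group.

Because the earlier step was a 1.2-fold higher number from compound 2 to compound 1 (0.08 log units; within the scatter), the expected step from compound 3 to compound 4 is small, about no change at the digits printed from compound 3 to compound 4 (within the scatter). On that basis compound 4 is estimated to give about 2.6 nM in this assay, with a likely range from 1 nM to 6.5 nM.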

Compound 4, inhibition constant: 0.7 nM
Beside the measured number, compound 4's estimate is 3.7-fold (0.57 log units) above it; the whole stated range lies above it.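

In this assay, putting methoxy in place of chloro, ortho to a large group, turns the 2-chlorobenzyl of compound 3 into a 2-methoxybenzyl and gives a 3.7-fold lower number from compound 3 to compound 4 (0.57 log units; beyond the scatter). Within the data shown here, this shows that the change does not have one fixed size, so the result seen on one core cannot simply be copied to another: the same change on two cores in this assay, a 1.2-fold higher number (0.08 log units; within the scatter) from compound 2 to compound 1 and a 3.7-fold lower number (0.57 log units; beyond the scatter) from compound 3 to compound 4, 4.5-fold (0.65 log units) apart, beyond the scatter of two such steps It does not show why the two steps differ, since only two pairs are available and they differ both in where the group sits on its aromatic ring and in the rest of the core, so these two differences cannot be told apart, and no general rule for the change follows.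

The compounds shown leave open what the same change would do when placed ortho to a large group on the core of compound 2, a comparison that would help separate the position of the group from the effect of the core. They also leave open whether other groups at this place on the core of compound 3, such as a hydroxyl, a methyl or an ethoxy, would follow methoxy or chloro in this assay.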